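Adding a chloro group to a vitamin D receptor antagonist

This account rests on a few compounds, and the source may have more. Where it says the series, first, only, none or still open, it means among the compounds named here.

Measured compounds:
- Compound 1, `CCC(CC)n1c(-c2ccc(OCc3c(-c4c(Cl)cccc4Cl)noc3C(C)C)cc2)nc2ccc(C(=O)O)cc21`: in an assay on HEK-293T cells for antagonist activity at vitamin D3 receptor (Homo sapiens), read by a luciferase reporter, with a stated time of 24 h (on this read-out lower numbers stand for stronger inhibition and higher numbers for weaker inhibition), compound 1 gives 5690 nM
- Compound 2, `CCCn1c(-c2ccc(OCc3c(-c4c(Cl)cccc4Cl)noc3C(C)C)cc2)nc2ccc(C(=O)O)cc21`: in this assay compound 2 gives 1400 nM

Going by the values given here, compound 1 stands at the highest of the two numbers, meaning the weaker inhibition of the pair; its only neighbour is compound 2, and a 4.1-fold lower number from compound 1 to compound 2 (0.61 log units; beyond the scatter) is the single step known so far. That step concerns the chain on the aromatic nitrogen of the shared core, not the ring.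

Compound 3, `CCC(CC)n1c(-c2ccc(OCc3c(-c4c(Cl)cccc4Cl)noc3C(C)C)cc2Cl)nc2ccc(C(=O)O)cc21`, is not yet measured. It differs from compound 1 by chloro in place of hydrogen on an aromatic carbon. Among the compounds with values here, no measured step touches this part of the structure, so the known step from compound 1 to compound 2 gives no direct guide. With nothing to point either way, compound 3 is expected to stay close to compound 1 in this assay, a step of a 1.4-fold lower number from compound 1 to compound 3 (0.15 log units; within the scatter). The estimate for compound 3 is therefore 4000 nM, with a range from 1200 nM to 13000 nM.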

Compound 3, half-maximal inhibitory concentration: 1010 nM
Compound 3: the middle estimate sits 4.0-fold (0.60 log units) above what was measured; measured number below the stated range.
By their numbers in this assay, from the lowest: compounds 3 and 2 (each within the scatter of the next); then compound 1.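

Going by these compounds alone, this is the first measured change on the six-membered aromatic ring of carbon only, and it shows that this ring is not a silent part of the molecule. In this assay, chloro in place of hydrogen, ortho to a large group and meta to a large group, gives a 5.6-fold lower number from compound 1 to compound 3 (0.75 log units; beyond the scatter) in a single change of one heavy atom. Within the data shown here, nothing measured so far explains why this chloro lowers the number.

Among these compounds, with only one group tested at this place, it remains open whether chloro itself matters or whether fluoro, methyl, methoxy or an amine would do the same. As far as these compounds go, it is also open whether chloro here and the shorter chain of compound 2 would lower the number further if combined in one compound.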